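Hydroxyl Added to the Aryl Ring of Compound 2

This account rests on a few compounds, and the source may have more. Where it says the series, first, only, none or still open, it means among the compounds named here.

Three compounds share one core. Compound 1 `Cc1ncc([N+](=O)[O-])n1CCSc1nnc(-c2ccccc2)o1` gives 20500 nM in a functional assay on MCF7 cells (Homo sapiens) for cytotoxicity, read by MTT assay, with a stated time of 48 h; on this read-out lower numbers stand for stronger inhibition and higher numbers for weaker inhibition. Compound 2 `Cc1ccccc1-c1nnc(SCCn2c([N+](=O)[O-])cnc2C)o1` gives 15800 nM in this assay, and compound 3 `Cc1ncc([N+](=O)[O-])n1CCSc1nnc(-c2ccccc2F)o1` gives 20500 nM. Compound 2 has the lowest of the three numbers, yet a 1.3-fold lower number from compound 1 to compound 2 (0.11 log units; within the scatter) and a 1.3-fold higher number from compound 2 to compound 3 (0.11 log units; within the scatter) both sit within the scatter, as does no change at the digits printed from compound 1 to compound 3 (within the scatter). Compound 4 `Cc1ccc(-c2nnc(SCCn3c([N+](=O)[O-])cnc3C)o2)c(O)c1` differs from compound 2 by 2-hydroxy-4-methylphenyl in place of 2-methylphenyl on an aromatic carbon. Within the data shown here, no measured step here introduces a hydrogen-bond donor; the three small steps on this aryl ring are the only guide, and none of them moved the number beyond the scatter. Compound 4 is therefore expected to give about 16000 nM, between 6000 nM and 42000 nM. The expected step is a 1.0-fold higher number from compound 2 to compound 4 (0.01 log units; within the scatter), nothing beyond the scatter.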

Compound 4, half-maximal inhibitory concentration: 23500 nM
For compound 4 the middle estimate is 1.5-fold (0.17 log units) below the measured one; the range from low to high includes it.
By their numbers in this assay, from the lowest: compounds 2, 1, 3 and 4 (each within the scatter of the next).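

In this assay the aryl group that carries a hydrogen-bond donor leaves the number within the scatter of all three earlier compounds: a 1.5-fold higher number from compound 2 to compound 4 (0.17 log units; within the scatter) and a 1.1-fold higher number from compound 3 to compound 4 (0.06 log units; within the scatter) and a 1.1-fold higher number from compound 1 to compound 4 (0.06 log units; within the scatter) are all small. This place on the shared core has therefore now accepted 2-hydroxy-4-methylphenyl, with its hydrogen-bond donor and acceptor, without a step beyond the scatter. From the compounds shown here alone, whether an amine or a carboxylic acid on this aryl ring would give a larger step remains open. Nothing available explains these numbers.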